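Thioether in place of azepane: expected potency

The source may report more compounds than this note shows. Statements on the series, on what has been measured and on what is new or still open speak of the compounds shown alone.

The series shares the core of compound 1 `CCCCN(C)c1cc(C(F)(F)F)ccc1CNC(=O)C(C)c1ccc(NS(C)(=O)=O)c(F)c1` and varies only the group on the aromatic carbon meta to the trifluoromethyl group. In an assay on CHO cells for antagonist activity at transient receptor potential cation channel subfamily V member 1 (Homo sapiens), read by FLIPR (a higher number here means a weaker inhibitor, a lower number a stronger inhibitor), compound 1 gives 1.2 nM. Compound 2 `CC(C(=O)NCc1ccc(C(F)(F)F)cc1N1CCCCCC1)c1ccc(NS(C)(=O)=O)c(F)c1` gives 1.6 nM in this assay, and compound 3 `CC(C(=O)NCc1ccc(C(F)(F)F)cc1OCc1ccc(F)cc1)c1ccc(NS(C)(=O)=O)c(F)c1` gives 0.5 nM in this assay. Compound 2 thus holds the highest of the three numbers; a 1.3-fold higher number from compound 1 to compound 2 (0.12 log units; within the scatter) lies within the scatter, while a 3.2-fold lower number from compound 2 to compound 3 (0.51 log units; beyond the scatter) and a 2.4-fold lower number from compound 1 to compound 3 (0.38 log units; beyond the scatter) are modest steps beyond it.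

Going by the values given here, compound 4 `CC(C(=O)NCc1ccc(C(F)(F)F)cc1SCc1ccccc1)c1ccc(NS(C)(=O)=O)c(F)c1` is not yet measured. benzylsulfanyl in place of azepan-1-yl on an aromatic carbon The one measured step that bears on this change is a 3.2-fold lower number from compound 2 to compound 3 (0.51 log units; beyond the scatter), where a benzyl-bearing group on the same aromatic carbon also displaced azepan-1-yl. Benzylsulfanyl differs from (4-fluorobenzyl)oxy in its linking atom and in lacking the ring fluorine, so the size is uncertain, but a modest lowering of the number is the expectation. For compound 4 the estimated step is a 2.3-fold lower number from compound 2 to compound 4 (0.36 log units; beyond the scatter) in this assay. Compound 4 is expected to give 0.7 nM in this assay, within 0.3 nM to 1.8 nM.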

Compound 4, inhibition constant: 0.5 nM
For compound 4 the middle estimate is 1.4-fold (0.15 log units) above the measured one; the range from low to high includes it.
By their numbers in this assay, from the lowest: compounds 3 and 4 (each within the scatter of the next); then compounds 1 and 2 (each within the scatter of the next).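

In this assay, sulfur-linked benzylsulfanyl and oxygen-linked (4-fluorobenzyl)oxy cannot be told apart (no change at the digits printed from compound 3 to compound 4 (within the scatter)), so the change of linking atom and the loss of the ring fluorine, taken together, leave the number where it was. The modest gain over the amino groups now appears with a second benzyl-bearing group, against both azepan-1-yl (a 3.2-fold lower number from compound 2 to compound 4 (0.51 log units; beyond the scatter)) and butyl(methyl)amino (a 2.4-fold lower number from compound 1 to compound 4 (0.38 log units; beyond the scatter)). No supporting data on hand account for this match between the two groups.

From the compounds shown here alone, the separate contributions of the linking atom and the ring fluorine remain open, and (4-fluorobenzyl)sulfanyl or plain benzyloxy on this carbon would separate them. Also open, going by these compounds, is whether the aromatic ring of the benzyl matters, a question for methylsulfanyl or cyclohexylmethylsulfanyl.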